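Replacing 4-Fluorophenyl with Pyridin-2-yl in a Cytotoxic Series

The source may hold more compounds than are shown below. What is called first, only, known or untested is meant among the compounds shown, and "the series" means these compounds.

In a functional assay on HL-60 cells (Homo sapiens) for cytotoxicity, read by CellTiter-Blue, with a stated time of 48 h (on this read-out lower numbers stand for stronger inhibition and higher numbers for weaker inhibition), compound 1 (`CCOC(=O)CC1C(C(=O)OC)=C(N)Oc2ccc(-c3cc(OC)cc(OC)c3)cc21`) gives 10800 nM and compound 2 (`C=CCOC(=O)CC1C(C(=O)OCC=C)=C(N)Oc2ccc(-c3cc(OC)cc(OC)c3)cc21`) gives 4700 nM, while compound 3 (`CCOC(=O)CC1C(C(=O)OCC)=C(N)Oc2ccc(-c3ccc(F)cc3)cc21`) gives 72100 nM as the highest of the three numbers. Compound 3 lies beyond the scatter from both others, but compounds 1 and 2 differ from it in more than one place, so no single structural change can be read from these values. Compound 4 (`CCOC(=O)CC1C(C(=O)OCC)=C(N)Oc2ccc(-c3ccccn3)cc21`) has pyridin-2-yl in place of 4-fluorophenyl on an aromatic carbon and is otherwise the same as compound 3. Among the compounds with values here, no measured pair shows a change at this place, so the expectation starts from compound 3 at 72100 nM and stays close to it. In this assay the expected step is a 1.8-fold lower number from compound 3 to compound 4 (0.26 log units; within the scatter) and so no larger than the scatter, leaning towards a lower number. Compound 4 is estimated at 40000 nM with a range from 12000 nM to 100000 nM as the expected span of a measurement.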

Compound 4, half-maximal inhibitory concentration: 76900 nM
For compound 4 the middle estimate is 1.9-fold (0.28 log units) below the measured one, and the stated range covers the measured number.
By their numbers in this assay, from the lowest: compound 2; then compound 1; then compounds 3 and 4 (each within the scatter of the next).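

In this assay, within the data shown here, the step of a 1.1-fold higher number from compound 3 to compound 4 (0.03 log units; within the scatter) is the first comparison that differs in one place only, and it shows that the exchange of 4-fluorophenyl for pyridin-2-yl on this aromatic carbon stays within the scatter. Going from a ring of carbon only to a ring with one hetero atom, which also brings one hydrogen-bond acceptor, therefore leaves no readable mark on the number at this position. No measurement at hand offers an explanation for this result.

Compounds 1 and 2 differ from compounds 3 and 4 in more than one place, so those steps cannot be read. As far as these compounds go, whether an aminophenyl group or a ring carrying a carboxylic acid at this position would move the number remains open.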